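A few compounds are considered here, and "the series" means these few. Any claim that something is new, unique, unknown or untested is made for them only; others in the source may bear on it.

Compound 1 `COc1ccc2nc(-c3ccc(N/C=C\C(=O)c4ccc(OC)c(O)c4)c(C)c3)sc2c1`: 18000 nM
Compound 2 `COc1ccc2nc(-c3ccc(N/C=C\C(=O)c4ccc(OC)c(O)c4)cc3)sc2c1`: 12800 nM

Going by the values given here, in a functional assay on A549 cells (Homo sapiens) for antiproliferative activity, read by sulforhodamine B assay, with a stated time of 48 h (on this read-out higher numbers stand for weaker inhibition and lower numbers for stronger inhibition), compound 1 gives 18000 nM and stands level with compound 2, the only other measured compound: a 1.4-fold lower number from compound 1 to compound 2 (0.15 log units; within the scatter). Compound 3 `COc1ccc2nc(-c3ccc(N/C=C\C(=O)c4ccc(OC)c(F)c4)c(C)c3)sc2c1` carries fluoro in place of hydroxy on an aromatic carbon. Among the compounds with values here, the one measured step, a 1.4-fold lower number from compound 1 to compound 2 (0.15 log units; within the scatter), is a different change, hydrogen in place of methyl, so it bears only indirectly. Within the data shown here, no measured step touches the hydroxy, so no direction can be argued and no shift beyond the scatter is expected. The expected step is a 1.1-fold higher number from compound 1 to compound 3 (0.05 log units; within the scatter). The estimate for compound 3 is 20000 nM, with an expected range of 8000 nM to 50000 nM.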

Compound 3, half-maximal inhibitory concentration: 1400 nM
Beside the measured number, compound 3's estimate is 14-fold (1.15 log units) above it; measured number outside the range, below it.
By their numbers in this assay, from the lowest: compound 3; then compounds 2 and 1 (each within the scatter of the next).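

Going by these compounds alone, changing 3-hydroxy-4-methoxyphenyl to 3-fluoro-4-methoxyphenyl gives, in this assay, a 13-fold lower number from compound 1 to compound 3 (1.11 log units; beyond the scatter), the first step beyond the scatter. The hydroxy is therefore not required for activity at this position, and this position responds far more clearly than the methyl change did. No measurement shown accounts for the size of this step.

Chloro, an amine or plain hydrogen at this position could separate a gain from fluoro itself from a gain from losing hydroxy. From the compounds shown here alone, whether the step holds on the core without the methyl remains open.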